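One Flipped Stereocentre in a Cell Tolerance Series

A few compounds are considered here, and "the series" means these few. Any claim that something is new, unique, unknown or untested is made for them only; others in the source may bear on it.

In an ADME assay on Vero cells (Chlorocebus sabaeus) for cytotoxicity, read by fluorescence and resazurin assay, with a stated time of 3 days (a higher number here means that more compound is tolerated, a lower number that less compound is tolerated), compound 1 `CCOC(=O)C[C@H]([C@H]1O[C@@H]2OC(C)(C)O[C@@H]2[C@H]1OCc1ccccc1)n1cnc2c(NCc3ccccc3)ncnc21` gives 53300 nM and compound 2 `CCCCCCCCCCCCNc1ncnc2c1ncn2[C@@H](CC(=O)OCC)[C@H]1O[C@@H]2OC(C)(C)O[C@@H]2[C@H]1OCc1ccccc1` gives 81500 nM as its reading, so these two numbers lie within the usual scatter of each other. Compound 3 `CCCCCCCCCCCCNc1ncnc2c1ncn2[C@H](CC(=O)OCC)[C@H]1O[C@@H]2OC(C)(C)O[C@@H]2[C@H]1OCc1ccccc1` is the next to be read, and its link to compound 2 is very close: the two compounds have the same atoms and bonds and differ only in configuration as drawn: 1 of 5 stereo elements differ; a stereocentre at a saturated chain carbon is drawn S in compound 2 and R in compound 3 in short, the two compounds have the same atoms and bonds, and a stereocentre at a saturated chain carbon is drawn S in compound 2 and R in compound 3. Within the data shown here, no measured pair here shows what such a change does to tolerance, so any forecast is cautious. The expected result is no shift beyond the scatter, with an estimated 1.1-fold lower number from compound 2 to compound 3 (0.04 log units; within the scatter) as the step. For compound 3 the estimated value is 75000 nM in a likely range from 40000 nM to 140000 nM as the expected bounds.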

Compound 3, half-maximal cytotoxic concentration: 45000 nM
Estimate against measurement, compound 3: 1.7-fold (0.22 log units) above; measured number inside the range.
By their numbers in this assay, from the lowest: compounds 3, 1 and 2 (each within the scatter of the next).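

In this assay, among these compounds, turning this saturated chain carbon from S to R gives a 1.8-fold lower number from compound 2 to compound 3 (0.26 log units; within the scatter), the first direct reading of what the configuration at this carbon does to tolerance. Any real effect in this pair could have only one source, because nothing else separates the two compounds: the fact that compounds 2 and 3 differ only in the configuration as drawn. Undecyl in place of phenyl on a saturated chain carbon bound to a nitrogen on an aromatic ring gives a 1.2-fold lower number from compound 1 to compound 3 (0.07 log units; within the scatter), so this swap also shows no readable effect on tolerance.

Among the compounds shown here, the configuration is seen in only one pair, so it remains open whether the same flip would read alike with the phenyl group of compound 1. Going by these compounds, it is also open how the flip would read in a compound carrying a carboxylic acid.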